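Swapping a Ring on a Hydroxamic Acid Chain

This account rests on a few compounds, and the source may have more. Where it says the series, first, only, none or still open, it means among the compounds named here.

Compound 1 `Cc1ccc(-c2noc(CCCCCCC(=O)NO)n2)cc1` with 5810 nM measured
Compound 2 `O=C(CCCCCCc1nc(-c2cccc([N+](=O)[O-])c2)no1)NO` with 10800 nM measured

Both numbers come from a functional assay on A549 cells (Homo sapiens) for antiproliferative activity, read by MTT assay, with a stated time of 72 h (on this read-out higher numbers stand for weaker inhibition and lower numbers for stronger inhibition), and they lie within the usual scatter of repeated measurements. Compound 1 therefore stands level with compound 2, and the two cannot be ranked.

Compound 3 `O=C(CCCCCCc1nc(-c2cccs2)no1)NO` has not yet been measured. Compared with compound 1 it has thiophen-2-yl in place of 4-methylphenyl on an aromatic carbon and the swap puts thiophen-2-yl in place of 4-methylphenyl on an aromatic carbon of a five-membered aromatic ring with 2 nitrogen and 1 oxygen.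

Among the measured compounds shown here, no pair of measured compounds differs in just one place, so the data offer no direct guide to the effect of this swap. For the measured compounds named here, the only anchors are compound 1 at 5810 nM and compound 2 at 10800 nM and these sit close together. A shift beyond the scatter is therefore not expected, and no direction is favoured. The expected change is a 1.2-fold higher number from compound 1 to compound 3 (0.08 log units; within the scatter) in this assay and it stays within the scatter. The expected value for compound 3 is 7000 nM (estimated range 2500 nM to 18000 nM).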

Compound 3, half-maximal inhibitory concentration: 4370 nM
Beside the measured number, compound 3's estimate is 1.6-fold (0.20 log units) above it; the range from low to high includes it.
By their numbers in this assay, from the lowest: compounds 3, 1 and 2 (each within the scatter of the next, the first and the last beyond it).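

In this assay, among the compounds shown here, the result is a 1.3-fold lower number from compound 1 to compound 3 (0.12 log units; within the scatter), which gives the first direct comparison at this position of the core. On an aromatic carbon between two ring nitrogen atoms, the six-membered carbon ring of 4-methylphenyl can give way to thiophen-2-yl, a five-membered aromatic ring containing sulfur, without a shift that stands out from the scatter. Nothing available here explains why the two groups read alike, and no cause can be given.

This single step changes ring size, ring atoms and the methyl group all at once, so it cannot separate their contributions; plain phenyl or furan-2-yl at the same carbon would help pull them apart. From the compounds shown here alone, it also remains open whether this position needs an aromatic ring at all, a question that a small non-aromatic group such as an amine or a carboxylic acid in the same place would address.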